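The compounds below may be only part of what the source reports. "The series", "measured", "known", "first", "only" and "open" are said of these compounds alone.

Three compounds measured in a functional assay on MGC-803 cells (Homo sapiens) for antiproliferative activity, read by MTT assay, with a stated time of 72 h (a lower number here means a stronger inhibitor, a higher number a weaker inhibitor), frame the question. Compound 1 `CCCSc1nc(N/N=C(\C)c2ccc(O)cc2)c2nnn(Cc3ccccc3)c2n1` gives 16700 nM in this assay, the highest number of the three. Compound 2 `C/C(=N\Nc1nc(SCc2ccccc2)nc2c1nnn2Cc1ccccc1)c1ccccc1O` gives 850 nM, and compound 3 `CCCSc1nc(N/N=C(\C)c2ccccc2O)c2nnn(Cc3ccco3)c2n1` gives 4760 nM; both values lie well below that of compound 1, so compound 1 is the weakest inhibitor of the three in this assay.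

Compound 4 `CCCSc1nc(N/N=C(\C)c2ccc(Br)cc2)c2nnn(Cc3ccccc3)c2n1` has not yet been measured. It differs from compound 1 in a single place: bromo in place of hydroxy on an aromatic carbon. For the measured compounds named here, no measured pair in this set shows the same change, so its effect cannot be read from the data at hand.

Given that compound 1 sits at the top of the observed numbers with 16700 nM, the expected step is a 2.1-fold lower number from compound 1 to compound 4 (0.32 log units; beyond the scatter), a modest move toward a lower number that may not clear the usual scatter. Compound 4 is accordingly estimated at 8000 nM, with a likely range from 2500 nM to 25000 nM.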

Compound 4, half-maximal inhibitory concentration: 6020 nM
The estimate for compound 4 lay 1.3-fold (0.12 log units) above the measured number; measured number inside the range.
By their numbers in this assay, from the lowest: compound 2; then compounds 3 and 4 (each within the scatter of the next); then compound 1.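

In this assay, for the compounds shown here, exchanging 4-hydroxyphenyl for 4-bromophenyl gives a 2.8-fold lower number from compound 1 to compound 4 (0.44 log units; beyond the scatter), the only single-place step in this set, and it shows that the number responds to the group on this aromatic carbon, para to a large group. The hydroxy, with its hydrogen-bond donor, is not needed for activity here, since bromo, with 0 hydrogen-bond donors, gives a modestly lower number. Nothing available explains why this exchange lowers the number.

The compounds shown leave open whether the step follows from losing the hydroxy or from gaining the bromo, and how chloro, methoxy or an amine would read at the same place. They also leave open whether the same exchange would give a similar step with the benzylthio group of compound 2 in place of the propylthio chain.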